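The source may hold more compounds than are shown below. What is called first, only, known or untested is meant among the compounds shown, and "the series" means these compounds.

Measured compounds:
Compound 1 `CC(=O)Nc1cccc(-c2ccc(C(=O)N(Cc3cccc(OCCCCCC(=O)O)c3)C(C)C)cc2)c1` gives > 26000 nM in an ADME assay on HepG2 cells (Homo sapiens) for cytotoxicity, read by CellTiter-Glo and resazurin assay, with a stated time of 72 h; on this read-out lower numbers stand for an effect already at smaller amounts and higher numbers for an effect only at larger amounts of compound.
Compound 2 `CC(C)N(Cc1cccc(OCCCCCC(=O)O)c1)C(=O)c1ccc(-c2cccc(-c3ccccc3)c2)cc1` gives > 26000 nM in this assay.
Compound 3 `CC(C)N(Cc1cccc(OCCCCCC(=O)O)c1)C(=O)c1ccc(-c2cccc(OCc3ccccc3)c2)cc1` gives > 26000 nM in this assay.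

Each of these three values is a limit of the assay, not a number. Compound 3 therefore stands at the limit, and the two other values sit at the same limit, as the limit of > 26000 nM in this assay, at which 3 of the 3 values shown sit, records. As a result, none of the steps between the measured compounds can be read: the change a step that the two limits leave unreadable from compound 1 to compound 2, the change a step that the two limits leave unreadable from compound 1 to compound 3 and the change a step that the two limits leave unreadable from compound 2 to compound 3 all leave the size unknown, since both ends are only limits.

Compound 4 `COc1cccc(-c2ccc(C(=O)N(Cc3cccc(OCCCCCC(=O)O)c3)C(C)C)cc2)c1` differs from compound 3 by hydrogen in place of phenyl on a saturated chain carbon bound to an oxygen on an aromatic ring, so the benzyloxy group becomes methoxy. The step from compound 2 to compound 3, which also altered the group on that aromatic carbon, is the closest measured comparison, but it was not readable. With every measured compound sitting at the limit and no readable step in this assay, there is no basis for expecting a step in either direction beyond the scatter; the expected step is a step that the limit leaves unreadable from compound 3 to compound 4. Compound 4 is therefore expected to give 35000 nM, with a range from 20000 nM to 80000 nM, and most likely it will again be reported only as a limit.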

Compound 4, half-maximal effective concentration: > 26000 nM
Compound 4 was reported as a limit; the forecaster's own chance of this, stated with the estimate: 85%; the middle value does not contradict the limit.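

Compound 4 also gives only a limit in this assay, so its steps from compound 1, compound 2 and compound 3 cannot be read, as all four compounds share the same limit: the limit of > 26000 nM in this assay, at which 4 of the 4 values shown sit.

The compounds shown leave open where the true value of each compound lies, and whether swapping the group on this aromatic carbon changes cytotoxicity at all.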